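Fluoro to acetoxy on the aromatic ring of the dienamide series

The source may report more compounds than this note shows. Statements on the series, on what has been measured and on what is new or still open speak of the compounds shown alone.

Of the compounds shown here, three sharing the dienamide core have been measured in an assay for inhibition of Polyunsaturated fatty acid 5-lipoxygenase (Homo sapiens), read by spectrophotometry, tested at 20 uM; on this read-out higher numbers stand for more inhibition at the one concentration tested (going by the name of the read-out) and lower numbers for less inhibition. Compound 1 `O=C(/C=C/C=C/c1ccc(Cl)cc1)N1CCCCC1` gives 14.5% in this assay. Compound 2 `O=C(/C=C/C=C/c1ccc(OC2CCCC2)cc1)N1CCCCC1` gives 16.1%, and compound 3 `O=C(/C=C/C=C/c1ccc(F)cc1)N1CCCCC1` gives 48.7%. Compound 3 stands highest of the three, with a number 34.2 percentage points higher from compound 1 to compound 3 (beyond the scatter) and a number 32.6 percentage points higher from compound 2 to compound 3 (beyond the scatter), while a number 1.6 percentage points higher from compound 1 to compound 2 (within the scatter) leaves compound 1 and compound 2 within the scatter of each other.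

Compound 4 `CC(=O)Oc1ccc(/C=C/C=C/C(=O)N2CCCCC2)cc1` is the next member, not yet measured in this assay. The change from compound 3 is acetoxy in place of fluoro on an aromatic carbon. The two steps that bear on it both end at compound 3 and both show that fluoro on that aromatic carbon gives a large gain over chloro and over cyclopentyloxy, as seen in a number 34.2 percentage points higher from compound 1 to compound 3 (beyond the scatter) and a number 32.6 percentage points higher from compound 2 to compound 3 (beyond the scatter). Going the other way, from fluoro to acetoxy, a step of similar size downward in this assay is therefore expected, toward the level of compound 1 and compound 2; the expected step is a number 30.7 percentage points lower from compound 3 to compound 4 (beyond the scatter). Compound 4 is estimated at 18%, with a range from 5% to 35%.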

Compound 4, a percentage reported as inhibition, at one concentration (the size of the read-out at that concentration, not a potency): 18.3%
Estimate against measurement, compound 4: 0.3 percentage points below; the range from low to high includes it.
By their numbers in this assay, from the lowest: compounds 1, 2 and 4 (each within the scatter of the next); then compound 3.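

In this assay fluoro remains the only group on this aromatic carbon with a high number, and a group with more heavy atoms and with hydrogen-bond acceptors does not retain it, as shown by a number 30.4 percentage points lower from compound 3 to compound 4 (beyond the scatter) in the move to acetoxy. Acetoxy joins chloro at one level, with a number 3.8 percentage points higher from compound 1 to compound 4 (within the scatter) between them. Exchanging cyclopentyl for acetyl on the oxygen on the aromatic ring also leaves the level in place, with a number 2.2 percentage points higher from compound 2 to compound 4 (within the scatter) as the step. No measurement bearing on the result accompanies these numbers, so the gap between fluoro and the other three groups stays unexplained.

The compounds shown leave open whether fluoro stands alone at this aromatic carbon or shares its level with hydrogen, hydroxyl or an amine there. Also open, from the compounds shown here alone, is whether the level of fluoro holds with a different amide group on the shared core.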